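A few compounds are considered here, and "the series" means these few. Any claim that something is new, unique, unknown or untested is made for them only; others in the source may bear on it.

This account follows three compounds measured in an ADME assay on RAW264.7 cells (Mus musculus) for cytotoxicity, read by MTT assay, with a stated time of 48 h; on this read-out lower numbers stand for higher toxicity in this test and higher numbers for lower toxicity in this test. Compound 1 `CC(=O)OC[C@H]1O[C@H](OC[C@@H](Cn2cc(CN(c3nc(-c4ccccc4)no3)C3CCCCC3)nn2)OC(C)=O)C=C[C@@H]1OC(C)=O` gives 28.6 ug/mL, compound 2 `CC(=O)OC[C@H]1O[C@H](OC[C@@H](CN=[N+]=[N-])OC(C)=O)C=C[C@@H]1OC(C)=O` gives 106 ug/mL, and compound 3 `C#CCN(c1nc(-c2ccc(C)cc2)no1)C1CCCCC1` gives 17.6 ug/mL. Compound 3 carries the lowest of the three numbers; its nearest neighbour is compound 1, which stands within the scatter of it, while compound 2 lies beyond the scatter. Compound 4 `C#CCN(c1nc(-c2ccc(F)cc2)no1)C1CCCCC1` differs from compound 3 by fluoro in place of methyl on an aromatic carbon; read one bond further out, the same difference runs from 4-methylphenyl to 4-fluorophenyl. Among the compounds with values here, no measured pair shows a step of this kind, so the account expects a step of a 1.0-fold higher number from compound 3 to compound 4 (0.01 log units; within the scatter) that stays within the scatter, in no firm direction. For compound 4 the estimate is 18 ug/mL, with a range from 9 ug/mL to 36 ug/mL.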

Compound 4, half-maximal cytotoxic concentration: 20.9 ug/mL
Compound 4: middle estimate off by 1.2-fold (0.06 log units), on the low side; low and high end bracket the measured number.
By their numbers in this assay, from the lowest: compounds 3, 4 and 1 (each within the scatter of the next); then compound 2.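

In this assay the only step shown at this place, a 1.2-fold higher number from compound 3 to compound 4 (0.07 log units; within the scatter), stays within the scatter. Fluoro in place of methyl on this aromatic carbon, para to a large group, therefore leaves 4-fluorophenyl and 4-methylphenyl with no readable difference in this test. No evidence bearing on this result is available. On these data alone, whether an amine or a carboxylic acid at the same place would likewise stay within the scatter remains open. So does whether any group here could move the number beyond it.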